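The compounds below may be only part of what the source reports. "The series", "measured", "known", "first", "only" and "open" are said of these compounds alone.

Values so far in an ADME assay on the whole organism (Mus musculus, strain CD-1) for pharmacokinetics, at a dose of 10 mg/kg by the oral route; on this read-out lower numbers stand for lower oral bioavailability and higher numbers for higher oral bioavailability
- compound 1 `COc1cc([C@](O)(CCN(C)C)[C@@H](c2cc3cc(C#N)ccc3nc2OC)c2cccc(C)c2F)cc(OC(F)F)n1` gives 66%
- compound 2 `CCSc1cc([C@](O)(CCN(C)C)[C@@H](c2cc3cc(C#N)ccc3nc2OC)c2cccc(OC)c2F)cc(SCC)n1` gives 24%

Compound 2 at 24% is the lower of the two numbers, and compound 1 stands beyond the scatter above it. Compound 3 `CCSc1cc([C@](O)(CCN(C)C)[C@@H](c2cc3cc(C#N)ccc3nc2OC)c2cccc(C)c2F)cc(SCC)n1` differs from compound 2 by methyl in place of methoxy on an aromatic carbon. Within the data shown here, no measured step shows this change, so only a small rise in this assay is expected, not clearly beyond the scatter. The estimate is an expected a number 6 percentage points higher from compound 2 to compound 3 (within the scatter) in this read-out. The expected value for compound 3 is 30% (range 14% to 50%).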

Compound 3, oral bioavailability: 22%
Compound 3: middle estimate off by 8 percentage points, on the high side, and the stated range covers the measured number.
By their numbers in this assay, from the lowest: compounds 3 and 2 (each within the scatter of the next); then compound 1.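

In this assay, methyl in place of methoxy on the aromatic carbon ortho to the fluoro group gives a number 2 percentage points lower from compound 2 to compound 3 (within the scatter), so this change does not separate the two compounds. With the 2-fluoro-3-methylphenyl group held constant, exchanging the sulfur-bearing aromatic group for the one carrying oxygen and fluorine in reverse gives a number 44 percentage points lower from compound 1 to compound 3 (beyond the scatter), which places the large gap at that other group. No measurement at hand accounts for either step. Open, on these data alone, is whether an ethyl or chloro group at this place would give a similar number, and whether methoxy and methyl also match alongside the aromatic group of compound 1.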